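A few compounds are considered here, and "the series" means these few. Any claim that something is new, unique, unknown or untested is made for them only; others in the source may bear on it.

Working notes on the solubility series. Compound 1 `N[C@@H](CSNC(=O)[C@@H](CCC(F)(F)F)N(Cc1ccc(-c2ncon2)cc1F)S(=O)(=O)c1ccc(Cl)cc1)C(=O)O` gives 260 ug/mL in a physicochemical assay for solubility, at pH 6.5; on this read-out higher numbers stand for higher solubility and lower numbers for lower solubility. Compound 2 `COC(=O)[C@@H](N)CSNC(=O)[C@@H](CCC(F)(F)F)N(Cc1ccc(-c2ncon2)cc1F)S(=O)(=O)c1ccc(Cl)cc1` gives 21 ug/mL in this assay; of the two numbers available it holds the lower, its nearest neighbour being compound 1 through a 12-fold lower number from compound 1 to compound 2 (1.09 log units; beyond the scatter). Compound 3 `O=C(NSc1ccccc1)[C@@H](CCC(F)(F)F)N(Cc1ccc(-c2ncon2)cc1F)S(=O)(=O)c1ccc(Cl)cc1` sits at a limit of this assay, < 1 ug/mL, which is the limit of < 1 ug/mL in this assay, at which 1 of the 3 values shown sits. The steps of an at least 260-fold lower number from compound 1 to compound 3 (2.41 log units; beyond the scatter) and an at least 21-fold lower number from compound 2 to compound 3 (1.32 log units; beyond the scatter) therefore both end at a limit rather than at a number.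

Compound 4 `CCOC(=O)[C@@H](N)CSNC(=O)[C@@H](CCC(F)(F)F)N(Cc1ccc(-c2ncon2)cc1F)S(=O)(=O)c1ccc(Cl)cc1` is not yet measured. It differs from compound 2 by methyl in place of hydrogen on a saturated chain carbon bound to an oxygen next to a carbonyl group. Going by the values given here, the only measured step of a comparable kind is a 12-fold lower number from compound 1 to compound 2 (1.09 log units; beyond the scatter), where a methyl entered on an oxygen next to a carbonyl group; the step to compound 4 adds a methyl one bond further out, on the carbon, and keeps the ester, so a smaller change is expected than the one from compound 1 to compound 2. For compound 4 a modest lowering in this assay is expected, a 1.8-fold lower number from compound 2 to compound 4 (0.24 log units; within the scatter), which may well sit within the scatter. Compound 4 is estimated at 12 ug/mL, with a range from 4 ug/mL to 35 ug/mL.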

Compound 4, solubility: 10 ug/mL
Beside the measured number, compound 4's estimate is 1.2-fold (0.08 log units) above it, and the stated range covers the measured number.
By their numbers in this assay, from the lowest: compound 4; then compound 2; then compound 1. At a limit, below all of these: compound 3.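

Methoxycarbonyl to ethoxycarbonyl gives a 2.1-fold lower number from compound 2 to compound 4 (0.32 log units; beyond the scatter) in this assay, so a single added methyl on a saturated chain carbon bound to an oxygen next to a carbonyl group still registers on this read-out. Ethyl in place of hydrogen on that oxygen gives a 26-fold lower number from compound 1 to compound 4 (1.41 log units; beyond the scatter), and the larger part of this drop already lies in the step to the methyl ester of compound 2. On the sulfur, 2-amino-2-(ethoxycarbonyl)ethyl in place of phenyl gives an at least 10-fold higher number from compound 3 to compound 4 (1.00 log units; beyond the scatter), a step that starts at a limit and not at a number: the limit of < 1 ug/mL in this assay, at which 1 of the 4 values shown sits.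

As far as these compounds go, whether a longer chain on the ester oxygen, such as propyl, or a branched one, such as isopropyl, lowers the number further stays open. The compounds shown also do not separate the amine from the carboxylic acid, since none carries one of these groups on the sulfur side chain without the other or an ester.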